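The compounds below may be only part of what the source reports. "The series", "measured", "known", "first", "only" and "open" are said of these compounds alone.

Compound 1 `CN1C(=O)CN(C2CCCC2)c2nc(Nc3ccc(N4CCCCC4)cc3)ncc21` and compound 3 `CCN1C(=O)CN(C2CCCC2)c2nc(Nc3ccc(N4CCCCC4)cc3)ncc21` share one core and differ in a single place, described by methyl in place of hydrogen on a saturated chain carbon bound to an amide-type nitrogen in a ring. In a functional assay on HT-29 cells (Homo sapiens) for inhibition, read by MTT assay, with a stated time of 48 h (on this read-out lower numbers stand for stronger inhibition and higher numbers for weaker inhibition), compound 1 gives 9860 nM. For compound 3 this assay reports only a limit, > 30000 nM. The resulting step is an at least 3.0-fold higher number from compound 1 to compound 3 (0.48 log units; beyond the scatter), a step that rests on the limit of > 30000 nM in this assay, at which 1 of the 3 values shown sits, rather than on two measured numbers. Compound 2 `CN1CCN(c2ccc(Nc3ncc4c(n3)N(C3CCCC3)CC(=O)N4C)nc2)CC1` gives 11100 nM in this assay; the difference between the cores of compound 1 and compound 2 is not broken down here. Compound 4 `CCN1C(=O)CN(C2CCCC2)c2nc(Nc3ccc(N4CCN(C)CC4)cn3)ncc21` carries the same change from compound 2, (methyl in place of hydrogen on a saturated chain carbon bound to an amide-type nitrogen in a ring). Going by the step seen from compound 1 to compound 3 an at least 3.0-fold higher number from compound 1 to compound 3 (0.48 log units; beyond the scatter), the expected step from compound 2 to compound 4 is a 3.2-fold higher number from compound 2 to compound 4 (0.50 log units; beyond the scatter). Compound 4 is therefore estimated at 35000 nM, between 15000 nM and 100000 nM.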

Compound 4, half-maximal inhibitory concentration: 7840 nM
Beside the measured number, compound 4's estimate is 4.5-fold (0.65 log units) above it, outside the stated range (below it).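

In this assay, methyl in place of hydrogen on the core of compound 2 gives a 1.4-fold lower number from compound 2 to compound 4 (0.15 log units; within the scatter). Set beside the earlier step, the same change does not carry over from one core to the other: the same change on two cores in this assay, an at least 3.0-fold higher number (0.48 log units; beyond the scatter) from compound 1 to compound 3 and a 1.4-fold lower number (0.15 log units; within the scatter) from compound 2 to compound 4, at least 4.3-fold (0.63 log units) apart, beyond the scatter of two such steps. With a single pair on each core, this does not show why the two steps part, and the value of compound 3 is only a limit: the limit of > 30000 nM in this assay, at which 1 of the 4 values shown sits.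

The compounds shown leave open how a longer chain such as propyl, or a chain ending in an amine, would read in place of the methyl on either core. They also leave open whether a further core would follow compound 1 and compound 3 or compound 2 and compound 4.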